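Extending the chain of compound 2: notes on compound 3

The compounds below may be only part of what the source reports. "The series", "measured", "known", "first", "only" and "open" are said of these compounds alone.

Among the compounds with values here, in a functional assay on MGC-803 cells (Homo sapiens) for antiproliferative activity, read by MTT assay, with a stated time of 48 h (a lower number here means a stronger inhibitor, a higher number a weaker inhibitor), compound 2 (`CCCCCCCCCCCCn1cc(COC[C@@H]2OC[C@H](N)[C@H]2O)nn1`) gives 115000 nM, the higher of the two numbers measured so far. Compound 1 (`CCCCCCCCCCCCCCCCCCn1cc(COC[C@@H]2OC[C@H](N)[C@@H]2O)nn1`) gives 15400 nM, and the gap between the two lies beyond the scatter. Compound 2 is therefore the weaker inhibitor of this pair.

The next compound to be read is compound 3 (`CCCCCCCCCCCCCCCCCCn1cc(COC[C@@H]2OC[C@H](N)[C@H]2O)nn1`). It carries hexyl in place of hydrogen on a saturated chain carbon, ten or more bonds along the chain from an aromatic nitrogen.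

Within the data shown here, with so few data, the only guide to direction is compound 1 at 15400 nM. A fall in the number, beyond the scatter, is expected in this assay. The expected step is a 4.6-fold lower number from compound 2 to compound 3 (0.66 log units; beyond the scatter). For compound 3 the estimated value is 25000 nM, with an expected range of 9000 nM to 70000 nM.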

Compound 3, half-maximal inhibitory concentration: 3110 nM
For compound 3 the middle estimate is 8.0-fold (0.91 log units) above the measured one; measured number below the stated range.
By their numbers in this assay, from the lowest: compound 3; then compound 1; then compound 2.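

In this assay, hexyl in place of hydrogen on a saturated chain carbon, ten or more bonds along the chain from an aromatic nitrogen, gives a 37-fold lower number from compound 2 to compound 3 (1.57 log units; beyond the scatter), a large step that shows this position of the chain responds strongly to added carbon. The series also responds to configuration, with a 5.0-fold lower number from compound 1 to compound 3 (0.69 log units; beyond the scatter), a modest step beyond the scatter at a stereocentre on a saturated ring carbon. That second step can be assigned to configuration as drawn alone, because of one fact about the pair: the fact that compounds 1 and 3 differ only in the configuration as drawn

Going by these compounds, whether a longer chain or a carboxylic acid in place of hexyl would move the number further remains open. The chain step is shown for only one configuration, and the configuration step for only one chain length, so the two effects cannot yet be read as independent.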